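Notes on the amine at the shared core

The source may hold more compounds than are shown below. What is called first, only, known or untested is meant among the compounds shown, and "the series" means these compounds.

Three analogues sharing one core have been measured. Compound 2 `OC1CCN(c2ncnc3[nH]cc(-c4cccc(Cl)c4)c23)CC1` gives 127 nM in an assay for inhibition of serine/threonine-protein kinase 3 (Homo sapiens), read by luminescence and ADP-Glo, in the presence of a further agent that is not named here (a lower number here means a stronger inhibitor, a higher number a weaker inhibitor), and carries the lowest number of the three; compound 1 `OCCCNc1ncnc2[nH]cc(-c3cccc(Cl)c3)c12` gives 173 nM, and compound 3 `CC1(N)CCN(c2ncnc3[nH]cc(-c4cccc(Cl)c4)c23)CC1` gives 278 nM. Compound 4 `CN(C)c1ncnc2[nH]cc(-c3cccc(Cl)c3)c12` is not yet measured; it differs from compound 2 by dimethylamino in place of 4-hydroxypiperidin-1-yl on an aromatic carbon. For the measured compounds named here, the steps that bear on this change are a 1.4-fold lower number from compound 1 to compound 2 (0.13 log units; within the scatter) and a 2.2-fold higher number from compound 2 to compound 3 (0.34 log units; beyond the scatter), together with a 1.6-fold higher number from compound 1 to compound 3 (0.21 log units; within the scatter); all are small. Changes at this same aromatic carbon have so far moved the number little, so compound 4 is expected to land close to compound 2, if anything somewhat higher. The expected step is a 2.0-fold higher number from compound 2 to compound 4 (0.29 log units; within the scatter). For compound 4 the estimate is 250 nM, with a range from 100 nM to 700 nM.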

Compound 4, half-maximal inhibitory concentration: 349 nM
The estimate for compound 4 lay 1.4-fold (0.14 log units) below the measured number, and the stated range covers the measured number.
By their numbers in this assay, from the lowest: compounds 2, 1, 3 and 4 (each within the scatter of the next, the first and the last beyond it).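

In this assay, for the compounds shown here, dimethylamino, with no ring and no hydrogen-bond donor, is the first group at this aromatic carbon to show a step beyond the scatter against 4-hydroxypiperidin-1-yl, other than 4-amino-4-methylpiperidin-1-yl (a 2.7-fold higher number from compound 2 to compound 4 (0.44 log units; beyond the scatter)). Against the other two groups it makes no readable difference (a 1.3-fold higher number from compound 3 to compound 4 (0.10 log units; within the scatter) and a 2.0-fold higher number from compound 1 to compound 4 (0.30 log units; within the scatter)), so the loss holds against compound 2 alone. Nothing available explains this step.

On these data alone, whether the ring or the hydroxyl of 4-hydroxypiperidin-1-yl carries the difference stays open. Unsubstituted piperidin-1-yl or morpholin-4-yl at this carbon would separate the two.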